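Adding chloro to the phenylsulfonyl group of compound 3

The source may hold more compounds than are shown below. What is called first, only, known or untested is meant among the compounds shown, and "the series" means these compounds.

Values in an ADME assay on microsomes from liver (Mus musculus) for metabolic stability, read by LC-MS, with NADPH named in the record, with a stated time of 60 min, tested at 1 uM, in the absence of a further agent (on this read-out lower numbers stand for a less stable compound and higher numbers for a more stable compound), are all limits and not numbers.
Compound 1 `COc1ccc(-c2c(C)nc3c(N4CC[C@@H](NC(=O)C(F)(F)F)C4)cc(C)nn23)cc1OC` gives > 95% as a limit
Compound 2 `COc1ccc(-c2c(C)nc3c(N4CC[C@@H](NS(=O)(=O)C5CC5)C4)cc(C)nn23)cc1OC` gives > 95% as a limit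
Compound 3 `COc1ccc(-c2c(C)nc3c(N4CC[C@@H](NS(=O)(=O)c5ccccc5)C4)cc(C)nn23)cc1OC` gives > 95% as a limit

Compound 3 has no exact position, and the series sits at the limit of > 95% in this assay, at which 3 of the 3 values shown sit, with no ranking to read. The change to compound 4 `COc1ccc(-c2c(C)nc3c(N4CC[C@@H](NS(=O)(=O)c5ccc(Cl)cc5)C4)cc(C)nn23)cc1OC` is chloro in place of hydrogen on an aromatic carbon and turns phenyl to 4-chlorophenyl. The closest measured change is a step that the two limits leave unreadable from compound 2 to compound 3 and gives no size. Neither a step that the two limits leave unreadable from compound 1 to compound 3 nor a step that the two limits leave unreadable from compound 1 to compound 2 gives a size either. Compound 3 at > 95% is a limit, so the expectation rests on that limit alone. A change of a step that the limit leaves unreadable from compound 3 to compound 4 is expected, with no clear direction and nothing beyond the scatter. Compound 4 is estimated at 96% with an expected range from 85% to 100% in this estimate.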

Compound 4, percent of the compound remaining: > 95%
Compound 4: only a limit was reported (the forecaster's own chance of this, stated with the estimate: 65%); the middle value lies beyond the limit too.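

In this assay compound 4 gives > 95%, a limit, and its steps from compound 1, compound 2 and compound 3 cannot be read: the limit of > 95% in this assay, at which 4 of the 4 values shown sit.

Going by these compounds, how the (trifluoromethyl)carbonyl, cyclopropylsulfonyl, phenylsulfonyl and (4-chlorophenyl)sulfonyl groups rank in this assay stays open.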